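Extending the chain of compound 2: expected effect

The compounds below may be only part of what the source reports. "The series", "measured", "known", "first", "only" and "open" are said of these compounds alone.

For the measured compounds named here, compound 2 `CCCCCCSC(=O)CS(=O)(=O)Nc1c(C(C)C)cccc1C(C)C` is the only member of the pair with a proper number: in an assay on microsomes from intestine for inhibition of acyl-CoA:cholesterol acyltransferase (Oryctolagus cuniculus) (a lower number here means a stronger inhibitor, a higher number a weaker inhibitor), compound 2 gives 1000 nM. Compound 1 `CCCCCCNC(=O)CS(=O)(=O)Nc1c(C(C)C)cccc1C(C)C` reaches only a limit in this assay, > 5000 nM. Going by the values given here, the single measured step, an at least 5.0-fold lower number from compound 1 to compound 2 (0.69 log units; beyond the scatter), is therefore bounded on one side by the limit of > 5000 nM in this assay, at which 1 of the 2 values shown sits, and its true size is not known beyond what the limit allows.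

Compound 3 `CCCCCCCCSC(=O)CS(=O)(=O)Nc1c(C(C)C)cccc1C(C)C` differs from compound 2 in one place: ethyl in place of hydrogen on a saturated chain carbon, six bonds along the chain from a sulfur. Among the compounds with values here, no measured step bears on this kind of change. Within the data shown here, the one step that has been measured concerns the exchange at the carbonyl carbon and leaves the length of the chain untouched, so it offers no guide to what extending the chain does.

With nothing to lean on, the working expectation for compound 3 is a number close to that of compound 2, a step of a 1.4-fold lower number from compound 2 to compound 3 (0.15 log units; within the scatter) that may well stay within the scatter of this assay. Compound 3 is accordingly estimated at 700 nM, with a range from 200 nM to 3000 nM.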

Compound 3, half-maximal inhibitory concentration: 150 nM
Compound 3: the middle estimate sits 4.7-fold (0.67 log units) above what was measured; measured number outside the range, below it.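

In this assay, the chain on the sulfur proves to be a sensitive place in the series: ethyl in place of hydrogen, six bonds along the chain from a sulfur, gives a 6.7-fold lower number from compound 2 to compound 3 (0.82 log units; beyond the scatter), the first measured effect of chain length, and it lies beyond the scatter. Together with the exchange at the carbonyl carbon, octylsulfanyl in place of hexylamino gives an at least 33-fold lower number from compound 1 to compound 3 (1.52 log units; beyond the scatter), so the change of chain and the exchange at the carbonyl carbon both lower the number across these three compounds. The full size of that larger step remains unknown, because compound 1 stands at a limit of the assay: the limit of > 5000 nM in this assay, at which 1 of the 3 values shown sits.

Two chain lengths on the sulfur define no trend and no optimum, so a decyl chain, or an octyl chain ending in an amine or a carboxylic acid, would show whether the number keeps falling or turns back. As far as these compounds go, it also remains open whether the gain from the longer chain carries over to the amide series, where an octylamino group would take the place of octylsulfanyl.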